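The source may hold more compounds than are shown below. What is called first, only, known or untested is meant among the compounds shown, and "the series" means these compounds.

Working notes on the series. Among the compounds with values here, in an ADME assay on microsomes from liver (Mus musculus) for metabolic stability, read by mass spectrometry, using NADPH, tested at 1.5 uM (on this read-out lower numbers stand for a shorter-lived compound and higher numbers for a longer-lived compound), compound 2 (`O=C(Nc1ccc2sc(-c3ccccc3)nc2c1)N1CCCCC1`) gives 0.283 h and compound 1 (`O=C(Nc1ccc2sc(-c3cccc(F)c3)nc2c1)N1CCCCC1`) gives 0.183 h as the only other measured number, so compound 2 stands within the scatter of its single neighbour. Compound 3 (`O=C(Nc1ccc2sc(-c3ccccc3)nc2c1)N1CCCC1`) keeps the shared core of compound 2 and alters the group on the carbonyl carbon (pyrrolidin-1-yl in place of piperidin-1-yl on a carbonyl carbon), with pyrrolidin-1-yl in place of piperidin-1-yl. Within the data shown here, the only measured step is a 1.5-fold higher number from compound 1 to compound 2 (0.19 log units; within the scatter) and it concerns hydrogen in place of fluoro on an aromatic carbon. Among the measured compounds shown here, no measured step covers the group on the carbonyl carbon, so the size and direction of this change remain open. With nothing to point either way, the expected 1.1-fold higher number from compound 2 to compound 3 (0.03 log units; within the scatter) stays within the scatter. Compound 3 is estimated at 0.3 h (expected range 0.13 h to 0.65 h).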

Compound 3, half-life: 0.3 h
Beside the measured number, compound 3's estimate shows no gap at the digits printed; low and high end bracket the measured number.
By their numbers in this assay, from the lowest: compounds 1, 2 and 3 (each within the scatter of the next).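

In this assay the group on the carbonyl carbon now has a measured step of its own, a 1.1-fold higher number from compound 2 to compound 3 (0.03 log units; within the scatter) and so the six-membered and five-membered non-aromatic rings at this place cannot be told apart on half-life. Compounds 1, 2 and 3 thus fall in a single band, each within the scatter of the next, and neither change read so far separates any of them. Nothing available bears on why the two rings read alike.

Open, as far as these compounds go, is whether a group of another kind on the carbonyl carbon, such as morpholin-4-yl with its ring oxygen or an open-chain diethylamino, would move the half-life beyond the scatter. Also open, from the compounds shown here alone, is whether pyrrolidin-1-yl reads the same when the fluoro of compound 1 is present.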